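The source may report more compounds than this note shows. Statements on the series, on what has been measured and on what is new or still open speak of the compounds shown alone.

Measured so far in a functional assay on CCRF-CEM cells (Homo sapiens) for antiproliferative activity, read by MTT assay, with a stated time of 24 h, tested at 25 uM; on this read-out lower numbers stand for a stronger effect and higher numbers for a weaker effect at the one concentration tested:
- compound 1, `OC(CCn1nc2c(Br)c(Br)c(Br)c(Br)c2n1)c1cccc(Br)c1`: 123%
- compound 2, `OC(CCn1nc2c(Br)c(Br)c(Br)c(Br)c2n1)c1ccc(F)cc1`: 104%
- compound 3, `OC(CCn1nc2c(Br)c(Br)c(Br)c(Br)c2n1)c1ccccc1`: 123%

Compound 3 stands level with compound 1 at the digits printed, the two together the highest of the three numbers; the step of no change at the digits printed from compound 1 to compound 3 (within the scatter) is within the scatter, so no order can be read between them. Compound 2 is the only one apart: a number 19 percentage points higher from compound 2 to compound 3 (beyond the scatter) is beyond the scatter, as is a number 19 percentage points lower from compound 1 to compound 2 (beyond the scatter).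

Compound 4, `OC(CCn1nc2c(Br)c(Br)c(Br)c(Br)c2n1)c1ccc(Br)cc1`, is still to be measured in this assay. Against compound 3 the change is bromo in place of hydrogen on an aromatic carbon, placed on an aromatic carbon of a six-membered aromatic ring of carbon only, para to a large group.

Among the measured compounds shown here, two measured steps bear on it. Removing bromo from an aromatic carbon, no change at the digits printed from compound 1 to compound 3 (within the scatter), made no difference. Removing fluoro from an aromatic carbon, a number 19 percentage points higher from compound 2 to compound 3 (beyond the scatter), raised the number by a modest amount; the reverse, putting a halogen on that position, lowered it. A bromo entering at the same place as the fluoro of compound 2 might therefore move the number somewhat down, but the bromo of compound 1 did nothing, so the expected step of a number 9 percentage points lower from compound 3 to compound 4 (within the scatter) is small and uncertain in direction. For compound 4 the estimate in this assay is 114%, with a range from 95% to 133%.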

Compound 4, a percentage reported as activity, at one concentration (the size of the read-out at that concentration, not a potency): 109%
For compound 4 the middle estimate is 5 percentage points above the measured one; low and high end bracket the measured number.
By their numbers in this assay, from the lowest: compounds 2 and 4 (each within the scatter of the next); then compounds 1 and 3 (each within the scatter of the next).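

In this assay, bromo on an aromatic carbon para to a large group is a change that registers: a number 14 percentage points lower from compound 3 to compound 4 (beyond the scatter) is a modest step beyond the scatter, which the bromo of compound 1 did not show, given no change at the digits printed from compound 1 to compound 3 (within the scatter) in the earlier data. Among the compounds shown here, the same atom therefore counts differently by where it sits on the phenyl, as a number 14 percentage points lower from compound 1 to compound 4 (beyond the scatter) shows for 4-bromophenyl in place of 3-bromophenyl, and among the three halogen-bearing compounds this is the first sign that the place of the halogen matters more than its presence alone. At this place the two halogens cannot be told apart, since a number 5 percentage points higher from compound 2 to compound 4 (within the scatter) lies within the scatter, so bromo and fluoro read as equivalent here and both sit apart from hydrogen in compound 3; nothing at hand gives a reason for any of these steps.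

On these data alone, what an amine or a carboxylic acid at this same place on the phenyl would do remains open, so the reading so far covers halogens only. Also open, as far as these compounds go, is whether a longer chain in place of the present saturated chain would move the number, and how any of these steps would look at concentrations other than the single one used in this assay for this series.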